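Extending the Amine Chain on Two Related Cores

The compounds below may be only part of what the source reports. "The series", "measured", "known", "first", "only" and "open" are said of these compounds alone.

Of the compounds shown here, three have been measured for antiproliferative activity. Compound 1 `CNCC(=O)Nc1cc(OC)ccc1C(=O)c1ccc2c(c1)C=CC(C)(C)O2` bears a methylamino group on its side chain, and in a functional assay on A549 cells (Homo sapiens) for antiproliferative activity, read by MTT assay, with a stated time of 48 h (a higher number here means a weaker inhibitor, a lower number a stronger inhibitor), compound 1 gives 800 nM. Compound 2 `CCNCC(=O)Nc1cc(OC)ccc1C(=O)c1ccc2c(c1)C=CC(C)(C)O2` differs from compound 1 only by methyl in place of hydrogen on a saturated chain carbon bound to an amine nitrogen; in this assay compound 2 gives 1300 nM. That single change produced a 1.6-fold higher number from compound 1 to compound 2 (0.21 log units; within the scatter), so the two values cannot be ordered with confidence.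

Compound 3 `CNCC(=O)Nc1cc(OC)ccc1C(=O)c1cc(OC)c(OC)c(OC)c1` rests on a different core; the difference between the two cores is not broken down here. In this assay compound 3 gives 610 nM, a value within the scatter of compound 1 and beyond the scatter of compound 2.

Compound 4 `CCNCC(=O)Nc1cc(OC)ccc1C(=O)c1cc(OC)c(OC)c(OC)c1` has not yet been measured. It differs from compound 3 by methyl in place of hydrogen on a saturated chain carbon bound to an amine nitrogen, the same change that separates compound 1 from compound 2, made at the same place on the chain. Among the compounds with values here, only that one earlier instance is available to guide an expectation, and it sits within the scatter, so little movement is anticipated. Because the same change gave a 1.6-fold higher number from compound 1 to compound 2 (0.21 log units; within the scatter), a step of similar size, a 1.6-fold higher number from compound 3 to compound 4 (0.19 log units; within the scatter), is expected here. Compound 4 is therefore estimated at 950 nM, with a likely range from 450 nM to 2100 nM.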

Compound 4, half-maximal inhibitory concentration: 750 nM
The estimate for compound 4 lay 1.3-fold (0.10 log units) above the measured number; the range from low to high includes it.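

Made on the core of compound 3, the change from methylamino to ethylamino gives a 1.2-fold higher number from compound 3 to compound 4 (0.09 log units; within the scatter) and so leaves the two values unordered in this assay. Set beside the earlier step on the core of compound 1, this second step gives no sign that the change behaves differently on the two cores: the same change on two cores in this assay, a 1.6-fold higher number (0.21 log units; within the scatter) from compound 1 to compound 2 and a 1.2-fold higher number (0.09 log units; within the scatter) from compound 3 to compound 4, 1.3-fold (0.12 log units) apart, within the scatter of two such steps. What this shows is limited to these two pairs: on both cores, ethylamino in place of methylamino leaves the number within the scatter, so in this series a step of this small size has so far carried from one core to the other, but two pairs do not make a general rule and do not prove that the change has no effect at all on any other core.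

The compounds shown leave open what a longer chain such as propylamino, a branched one such as isopropylamino, a tertiary amine such as dimethylamino or a cyclic amine such as pyrrolidine would do on either core. They also leave open whether the same small steps would appear anywhere other than in this assay.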